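From Methoxy to Ethoxy in a Small Antiproliferative Series

The source may report more compounds than this note shows. Statements on the series, on what has been measured and on what is new or still open speak of the compounds shown alone.

Measured in a functional assay on MCF7 cells (Homo sapiens) for antiproliferative activity, read by MTT assay, with a stated time of 72 h; on this read-out lower numbers stand for stronger inhibition and higher numbers for weaker inhibition:
- compound 1 `CCOc1ccc(-c2sc(N(C)C)nc2-c2cc(OC)c(OC)c(OC)c2)cc1`: > 10000 nM (a limit)
- compound 2 `COc1cc(-c2nc(C)sc2-c2ccc(C(F)(F)F)cc2)cc(OC)c1OC`: > 10000 nM (a limit)
- compound 3 `COc1ccc(-c2sc(C)nc2-c2cc(OC)c(OC)c(OC)c2)cc1`: 606 nM

Compound 3 alone has a true number. The other two sit at the limit of > 10000 nM in this assay, at which 2 of the 3 values shown sit.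

Compound 4 `CCOc1ccc(-c2sc(C)nc2-c2cc(OC)c(OC)c(OC)c2)cc1` follows from compound 3 by one change, methoxy to ethoxy: methyl in place of hydrogen on a saturated chain carbon bound to an oxygen on an aromatic ring.

Among the measured compounds shown here, the only measured step that alters this group is an at least 16-fold lower number from compound 2 to compound 3 (1.21 log units; beyond the scatter). It is large, but it is a different swap, so a smaller move toward weaker inhibition is expected in this assay. The expected change is a 2.5-fold higher number from compound 3 to compound 4 (0.39 log units; beyond the scatter). For compound 4 the estimated value is 1500 nM, within an expected range of 250 nM to 9000 nM.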

Compound 4, half-maximal inhibitory concentration: 42.3 nM
Compound 4: middle estimate off by 35-fold (1.55 log units), on the high side; measured number below the stated range.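

Lengthening the methoxy of compound 3 to the ethoxy of compound 4 adds a single methyl, yet it gives a 14-fold lower number from compound 3 to compound 4 (1.16 log units; beyond the scatter), so this position responds strongly even to the smallest extension of the chain. With the ethoxy in place, trifluoromethyl and dimethylamino can also be set against compound 4: ethoxy in place of trifluoromethyl gives an at least 230-fold lower number from compound 2 to compound 4 (2.37 log units; beyond the scatter), and methyl in place of dimethylamino gives an at least 230-fold lower number from compound 1 to compound 4 (2.37 log units; beyond the scatter). Both steps start from a limit rather than a number: the limit of > 10000 nM in this assay, at which 2 of the 4 values shown sit.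

From the compounds shown here alone, whether a longer chain such as propoxy extends the gain or reverses it stays open. So does whether a branched isopropoxy or a free hydroxyl at this place would keep it.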